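Sulfonyl aryl exchange in a piperidinyl series: compound 4

The compounds below may be only part of what the source reports. "The series", "measured", "known", "first", "only" and "open" are said of these compounds alone.

Compound 2 `CC1CCN(c2c(S(=O)(=O)c3cccc(C#N)c3)cnc3ccc(Cl)cc23)CC1` gives 90% in an assay on isolated protein for displacement of a labelled ligand from metabotropic glutamate receptor 5 (Homo sapiens), with a stated time of 60 min, tested at 1 uM (on this read-out higher numbers stand for more inhibition at the one concentration tested (going by the name of the read-out) and lower numbers for less inhibition), the second highest of the three measured numbers. Its nearest neighbour is compound 3 `CC1CCN(c2c(S(=O)(=O)c3cccc(C#N)c3)cnc3ccc(F)cc23)CC1`, which gives 93%; the furthest is compound 1 `CC1CCN(c2c(S(=O)(=O)c3ccc(Cl)c(Cl)c3)cnc3ccc(Cl)cc23)CC1`, which gives 86%. Both steps, a number 3 percentage points higher from compound 2 to compound 3 (within the scatter) and a number 4 percentage points higher from compound 1 to compound 2 (within the scatter), stay within the scatter. Compound 4 `CC1CCN(c2c(S(=O)(=O)c3ccc(F)cc3)cnc3ccc(Cl)cc23)CC1` differs from compound 2 by 4-fluorophenyl in place of 3-cyanophenyl on a sulfonyl sulfur. Within the data shown here, only one measured step concerns the group on the sulfonyl sulfur, namely a number 4 percentage points higher from compound 1 to compound 2 (within the scatter), and it did not exceed the scatter; the other, a number 3 percentage points higher from compound 2 to compound 3 (within the scatter), touches a different position. A step beyond the scatter in this assay is therefore not expected in either direction. Compound 4 is estimated at 85%, with a range of 72% to 95%, an expected step of a number 5 percentage points lower from compound 2 to compound 4 (within the scatter).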

Compound 4, a percentage reported as inhibition, at one concentration (the size of the read-out at that concentration, not a potency): 89%
Beside the measured number, compound 4's estimate is 4 percentage points below it; the measured number falls inside the stated range.
By their numbers in this assay, from the lowest: compounds 1, 4, 2 and 3 (each within the scatter of the next).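

On the sulfonyl sulfur, 4-fluorophenyl is a third aryl group in this assay that shows no step beyond the scatter, with a number 1 percentage points lower from compound 2 to compound 4 (within the scatter) and a number 3 percentage points higher from compound 1 to compound 4 (within the scatter) as its two readings. The nitrile of the 3-cyanophenyl group and its hydrogen-bond acceptor can therefore be given up at this position without a step beyond the scatter. No measured evidence bears on why these numbers stay so close.

On these data alone, whether a carboxylic acid or an amine on the aryl ring would leave the number within the scatter remains open. So does the effect of a plain alkyl chain on the sulfonyl sulfur in place of the aryl ring.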